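A few compounds are considered here, and "the series" means these few. Any claim that something is new, unique, unknown or untested is made for them only; others in the source may bear on it.

Measured so far:
compound 1 `O=C(Nc1cccc(C(F)(F)F)c1)C1c2ccccc2CCN1C(=O)c1ccc(Cl)cc1`: > 10000 nM
compound 2 `O=C(Nc1cccc(C(F)(F)F)c1)C1NCCc2ccccc21`: > 10000 nM
compound 3 `COc1ccc(NC(=O)C2NCCc3ccccc32)cc1`: > 10000 nM

In a functional assay on NUGC-3 cells (Homo sapiens) for inhibition, read by sulforhodamine B assay, with a stated time of 48 h (a higher number here means a weaker inhibitor of growth, a lower number a stronger inhibitor of growth), compound 1 gives > 10000 nM, which is a limit of the assay and not a number. Compound 2 likewise gives only a limit, > 10000 nM. Compound 3 also stops at a limit, > 10000 nM. All three values sit at the limit of > 10000 nM in this assay, at which 3 of the 3 values shown sit, so compound 1 stands at the limit with nothing measured beyond it. Going by the values given here, the one single-point step, a step that the two limits leave unreadable from compound 1 to compound 2, is therefore unreadable.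

Compound 4 `COc1ccccc1NC(=O)C1c2ccccc2CCN1C(=O)c1ccc(Cl)cc1` differs from compound 1 by 2-methoxyphenyl in place of 3-(trifluoromethyl)phenyl on an amide-type nitrogen. Among the compounds with values here, no measured step touches the aryl on the amide-type nitrogen, so no size for this change can be read from the series; compound 1 and compound 3 both show only limits, which tells nothing about direction. With every value at the limit, compound 4 is expected to remain there as well, the expected step that the limit leaves unreadable from compound 1 to compound 4 being essentially none beyond the scatter. The estimate for compound 4 in this assay is 15000 nM, between 3000 nM and 60000 nM.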

Compound 4, concentration for 50% growth inhibition: 1590 nM
The estimate for compound 4 lay 9.4-fold (0.97 log units) above the measured number; the whole stated range lies above it.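

In this assay, the aryl on the amide-type nitrogen turns out to matter: 2-methoxyphenyl in place of 3-(trifluoromethyl)phenyl gives an at least 6.2-fold lower number from compound 1 to compound 4 (0.79 log units; beyond the scatter). With the rest of the core of compound 1 unchanged, this single change brings the series off the limit, and compound 4 holds the only true number among the compounds shown. On these data alone, the step is a minimum and its full size stays unknown, because compound 1 gives a limit and not a number: the limit of > 10000 nM in this assay, at which 3 of the 4 values shown sit.

Whether the effect comes from the methoxy group itself remains open, as no other group, such as a hydroxyl, an ethoxy or an amine, is shown in its place on this ring. Also open is whether it depends on the (4-chlorophenyl)carbonyl on the ring amine nitrogen, since no compound shown pairs 2-methoxyphenyl with any other group there.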